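Swapping bromo for fluoro on a shared quinoline-free core

The source may hold more compounds than are shown below. What is called first, only, known or untested is meant among the compounds shown, and "the series" means these compounds.

Of the compounds shown here, three of one shared core have been measured in a functional assay on MCF7 cells (Homo sapiens) for inhibition, read by MTT assay, with a stated time of 24 h; a lower number here means a stronger inhibitor, a higher number a weaker inhibitor. Compound 1 `N#Cc1ccc2nc(-c3cccc(Oc4ccccc4)c3)cc(-c3ccccc3)c2c1` carries a cyano group and gives 822 nM. Compound 2 `Clc1ccc2nc(-c3cccc(Oc4ccccc4)c3)cc(-c3ccccc3)c2c1` carries chloro in its place and gives 11000 nM. Compound 3 `Brc1ccc2nc(-c3cccc(Oc4ccccc4)c3)cc(-c3ccccc3)c2c1` carries bromo and gives 11100 nM. Among the compounds with values here, on these numbers compound 3 stands highest of the three, but the nearest step is a 1.0-fold higher number from compound 2 to compound 3 (0.00 log units; within the scatter), so those two cannot be told apart; only the steps of a 13-fold higher number from compound 1 to compound 2 (1.13 log units; beyond the scatter) and a 14-fold higher number from compound 1 to compound 3 (1.13 log units; beyond the scatter) are clear.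

Compound 4 `Fc1ccc2nc(-c3cccc(Oc4ccccc4)c3)cc(-c3ccccc3)c2c1` has not yet been measured. It differs from compound 3 in one place: fluoro in place of bromo on an aromatic carbon. The step that bears on it most closely is the one from chloro to bromo, a 1.0-fold higher number from compound 2 to compound 3 (0.00 log units; within the scatter), where a change of one halogen-type substituent for another left the number where it was. The large steps from compound 1 involved the cyano group, which is not part of this change. Compound 4 is therefore expected to sit close to compound 3, with a step of a 1.1-fold lower number from compound 3 to compound 4 (0.05 log units; within the scatter) in this assay. The estimate for compound 4 is 10000 nM, with a range from 3500 nM to 30000 nM.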

Compound 4, half-maximal inhibitory concentration: 1680 nM
For compound 4 the middle estimate is 6.0-fold (0.77 log units) above the measured one; measured number outside the range, below it.
By their numbers in this assay, from the lowest: compound 1; then compound 4; then compounds 2 and 3 (each within the scatter of the next).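

In this assay the halogens at this position do not behave as one family: chloro and bromo could not be told apart, yet fluoro gives a 6.6-fold lower number from compound 3 to compound 4 (0.82 log units; beyond the scatter) and a 6.5-fold lower number from compound 2 to compound 4 (0.82 log units; beyond the scatter). Cyano still gives the lowest number of the four, but the remaining gap is a 2.0-fold higher number from compound 1 to compound 4 (0.31 log units; beyond the scatter), so the large drop seen on leaving cyano holds for chloro and bromo and is much smaller for fluoro. A swap of one heavy atom for one heavy atom on this aromatic carbon, with no hydrogen-bond donors or acceptors on either side, can therefore move the number well beyond the scatter, and the earlier match between chloro and bromo gave no sign of this.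

No measurement is available that explains why fluoro parts from chloro and bromo, so the reason stays open. Also open, from the compounds shown here alone, is whether a methoxy group, an amine or a carboxylic acid on this carbon would land nearer compound 1 or nearer compound 2, and whether the same order would hold in another cell line.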